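A few compounds are considered here, and "the series" means these few. Any claim that something is new, unique, unknown or untested is made for them only; others in the source may bear on it.

Measured compounds:
Compound 1 `CC(C)C[C@H](N)c1cc(C(F)(F)F)ccc1N1CCN(C(=O)[C@H]2C[S+]([O-])C[C@@H]2c2ccc(Cl)cc2)CC1` gives 120 nM in an assay on HEK293 cells for displacement of a labelled ligand from Melanocortin receptor 4 (Homo sapiens); on this read-out higher numbers stand for weaker inhibition and lower numbers for stronger inhibition.
Compound 2 `CC(C)C[C@H](N)c1cc(C(F)(F)F)ccc1N1CCN(C(=O)[C@H]2CS(=O)(=O)C[C@@H]2c2ccc(Cl)cc2)CC1` gives 38 nM in this assay.
Compound 3 `CC(C)C[C@H](N)c1cc(C(F)(F)F)ccc1N1CCN(C(=O)C2C(=O)OCC2c2ccc(Cl)cc2)CC1` gives 260 nM in this assay.

Among the three compounds measured so far, compound 2 stands at the lowest number, and its distance to each of the other two lies beyond the scatter of repeated measurements: compound 1 sits above it, and compound 3 sits further above still. The three share a common core and differ only in the ring that carries the chlorophenyl group, so nothing among them speaks to a change at the amine.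

The unmeasured compound 4 `CC(C)C[C@H](NCCN(C)C)c1cc(C(F)(F)F)ccc1N1CCN(C(=O)[C@H]2CS(=O)(=O)C[C@@H]2c2ccc(Cl)cc2)CC1` keeps everything of compound 2 and alters the amine alone: 2-(dimethylamino)ethyl in place of hydrogen on an amine nitrogen. Among the measured compounds shown here, no pair among the measured compounds isolates a change at this position, so there is no measured step to lean on, and the direction of the effect cannot be read from the data.

Compound 4 is therefore expected to land close to compound 2, with a step of a 2.1-fold higher number from compound 2 to compound 4 (0.32 log units; beyond the scatter) that may be small in either direction. The estimate for compound 4 in this assay is 80 nM, with a range from 15 nM to 400 nM.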

Compound 4, inhibition constant: 170 nM
The estimate for compound 4 lay 2.1-fold (0.33 log units) below the measured number; the measured number falls inside the stated range.
By their numbers in this assay, from the lowest: compound 2; then compounds 1, 4 and 3 (each within the scatter of the next, the first and the last beyond it).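

Putting 2-(dimethylamino)ethyl in place of hydrogen on the amine nitrogen gives a 4.5-fold higher number from compound 2 to compound 4 (0.65 log units; beyond the scatter) in this assay, a modest step that lies beyond the scatter. Among the compounds shown here, this is the only measured step at this position, and it settles the direction that the earlier compounds could not show: for this change on the core of compound 2, the number rises rather than falls. It also shows that the amine nitrogen can carry this chain and still give a measurable number in the same assay, while the data offer no explanation for the rise.

Open, going by these compounds, is whether the step follows from the terminal dimethylamino nitrogen or from the chain itself, a question that a methyl, an n-butyl chain or a 2-hydroxyethyl group on the same nitrogen could help to separate. Also open, on these data alone, is whether the same change would give a step of similar size on the cores of compound 1 and compound 3, where the group around the chlorophenyl-bearing ring differs.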